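The source may hold more compounds than are shown below. What is called first, only, known or untested is meant among the compounds shown, and "the series" means these compounds.

Measured compounds:
compound 1 `CCCC(=O)n1nc(C)c(-c2ccc(Cl)c(Cl)c2)c1N`: in an assay on Sf9 cells for inhibition of mitogen-activated protein kinase kinase kinase 14 (Homo sapiens), read by ADP-Glo, with a stated time of 60 min (on this read-out lower numbers stand for stronger inhibition and higher numbers for weaker inhibition), compound 1 gives > 100000 nM, which is a limit of the assay and not a number.
compound 2 `Cc1nn(C(=O)C2CCCC2)c(N)c1-c1ccc(Cl)c(Cl)c1`: in this assay compound 2 gives 41000 nM.

Going by the values given here, compound 2 therefore holds the only number in this assay; the other entry is a limit, as recorded in the limit of > 100000 nM in this assay, at which 1 of the 2 values shown sits. Among the compounds with values here, the single measured step, an at least 2.4-fold lower number from compound 1 to compound 2 (0.38 log units; beyond the scatter), came with cyclopentyl in place of propyl on a carbonyl carbon.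

Compound 3 `Cc1nn(C(=O)c2cccnc2)c(N)c1-c1ccc(Cl)c(Cl)c1` differs from compound 2 by pyridin-3-yl in place of cyclopentyl on a carbonyl carbon. Within the data shown here, that measured step exchanged one carbon group for another on the same carbonyl carbon; the present change exchanges cyclopentyl for pyridin-3-yl, a replacement that none of the measured compounds covers, so the measured step bears on it only by sharing the position. With no closer guide, the expected step from compound 2 to compound 3 is a 1.0-fold lower number from compound 2 to compound 3 (0.01 log units; within the scatter), nothing beyond the scatter. Compound 3 is estimated at 40000 nM in this assay, within 10000 nM to 100000 nM.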

Compound 3, half-maximal inhibitory concentration: > 100000 nM
Compound 3: no number, only a limit; the forecaster's own chance of this, stated with the estimate: 35%; middle value at least 2.5-fold (0.39 log units) from the limit.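

In this assay compound 3 gives > 100000 nM, which is a limit of the assay and not a number. Even so, the change can be read as an at least 2.4-fold higher number from compound 2 to compound 3 (0.38 log units; beyond the scatter), so on this carbonyl carbon pyridin-3-yl does not hold the level reached with cyclopentyl, and the position has now responded to two different exchanges. The step between compound 1 and compound 3 cannot be read, and compound 2 alone keeps a number, with the other two entries resting at the same limit: the limit of > 100000 nM in this assay, at which 2 of the 3 values shown sit.

As far as these compounds go, how far compound 3 lies beyond that limit stays open. So does whether the step follows the ring nitrogen or the aromatic ring, a question that phenyl on the same carbonyl carbon could address, while cyclohexyl could show whether the gain seen with cyclopentyl extends to a larger carbon ring.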